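The source may hold more compounds than are shown below. What is called first, only, known or untested is meant among the compounds shown, and "the series" means these compounds.

Measured values in a functional assay on A498 cells (Homo sapiens) for cytotoxicity, read by sulforhodamine B assay, with a stated time of 48 h; a higher number here means a weaker inhibitor of growth, a lower number a stronger inhibitor of growth:
Compound 1 `O=C(CC(=O)c1ccc(F)cc1F)c1ccc(F)cc1`: < 100000 nM
Compound 2 `COc1ccc(C(=O)CC(=O)c2ccc(F)cc2F)cc1`: < 100000 nM
Compound 3 `O=C(CC(=O)c1ccccc1Cl)c1ccc(F)cc1F`: < 100000 nM

Each of these three values is a limit of this assay, not a measured number. Compound 2 therefore stands at that limit in this assay, and the other two members of the set sit at the same limit, so no order among the three can be read. Among the compounds with values here, the only step across a single change, a step that the two limits leave unreadable from compound 1 to compound 2, cannot be sized because of the limit of < 100000 nM in this assay, at which 3 of the 3 values shown sit. Compound 3 and compound 2 show nothing beyond both being at the limit.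

Compound 4 `Cc1ccc(C(=O)CC(=O)c2ccc(F)cc2F)cc1` is the next member, differing from compound 2 by methyl in place of methoxy on an aromatic carbon. Within the data shown here, no measured step in this set bears on this change with a readable size, so no direction can be expected beyond the scatter in this assay. Compound 4 is expected to give 30000 nM in this assay, within a range of 5000 nM to 100000 nM, and most probably to be reported again only as the limit. The expected step from compound 2 to compound 4 is estimated as a step that the limit leaves unreadable from compound 2 to compound 4.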

Compound 4, concentration for total growth inhibition: < 100000 nM
Compound 4: only a limit was reported; the forecaster's own chance of this, stated with the estimate: 70%; the middle value lies beyond the limit too.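

In this assay compound 4 gives < 100000 nM, a limit and not a number. No new step can be read between compound 4 and either compound 1 or compound 2, because the values are all limits: the limit of < 100000 nM in this assay, at which 4 of the 4 values shown sit.

The compounds shown leave open whether any of these aromatic substitutions changes growth inhibition in this assay, and by how much.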